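This account rests on a few compounds, and the source may have more. Where it says the series, first, only, none or still open, it means among the compounds named here.

Series notes. Compound 1 `CC[C@H](C)[C@H](NC(=O)c1cnc2ccccc2c1Cl)C(=O)OC`, compound 2 `COC(=O)[C@@H](NC(=O)c1cnc2ccccc2c1Cl)C(C)C` and compound 3 `COC(=O)[C@@H](NC(=O)c1cnc2ccccc2c1Cl)[C@@H](C)O` have been run in an ADME assay on CCRF-CEM cells (Homo sapiens) for cytotoxicity; on this read-out lower numbers stand for higher toxicity in this test and higher numbers for lower toxicity in this test. Compound 1 gives 23.3 uM and compound 2 gives 17.6 uM. Compound 3 gives > 100 uM, which is a limit of the assay and not a number (the limit of > 100 uM in this assay, at which 1 of the 3 values shown sits). The step of a 1.3-fold lower number from compound 1 to compound 2 (0.12 log units; within the scatter) arises from hydrogen in place of methyl on a saturated chain carbon, three bonds along the chain from an amide-type nitrogen and a carbonyl carbon. The hydroxy-bearing compound stands apart: an at least 4.2-fold higher number from compound 1 to compound 3 (0.63 log units; beyond the scatter) and an at least 5.6-fold higher number from compound 2 to compound 3 (0.75 log units; beyond the scatter).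

Compound 4 `COC(=O)[C@H](CO)NC(=O)c1cnc2ccccc2c1Cl` is not yet measured in this assay. Going by the values given here, it differs from compound 3 by hydrogen in place of methyl on a saturated chain carbon bound to an oxygen on a saturated carbon and a saturated chain carbon, the same kind of change as the one from compound 1 to compound 2, though the surroundings differ: the earlier one sits on a saturated chain carbon, three bonds along the chain from an amide-type nitrogen and a carbonyl carbon, the new one on a saturated chain carbon bound to an oxygen on a saturated carbon and a saturated chain carbon. The cores of compound 1 and compound 3 differ by hydroxy in place of ethyl on a saturated chain carbon bound to two saturated chain carbons. The earlier methyl-to-hydrogen change gave a 1.3-fold lower number from compound 1 to compound 2 (0.12 log units; within the scatter). On that basis a step that the limit leaves unreadable from compound 3 to compound 4 is expected for compound 4, which would leave it at the limit. Compound 4 is estimated at 120 uM, between 50 uM and 300 uM.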

Compound 4, half-maximal toxic concentration: > 100 uM
Compound 4 ended at the assay's limit; the forecaster's own chance of this, stated with the estimate: 75%; the middle value does not contradict the limit.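

In this assay compound 4 gives > 100 uM, which is a limit of the assay and not a number. Against the alkyl side chains, hydroxymethyl gives an at least 5.6-fold higher number from compound 2 to compound 4 (0.75 log units; beyond the scatter) and an at least 4.2-fold higher number from compound 1 to compound 4 (0.63 log units; beyond the scatter), so the high reading seen with 1-hydroxyethyl holds for hydroxymethyl as well. What the change from methyl to hydrogen does on the core of compound 3 cannot be read, and it cannot be set against a 1.3-fold lower number from compound 1 to compound 2 (0.12 log units; within the scatter), so nothing shows whether that change carries over from one core to the other, because both compounds with the hydroxy group sit at the limit: the limit of > 100 uM in this assay, at which 2 of the 4 values shown sit.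

The compounds shown leave open how far past the limit compound 3 and compound 4 lie, and whether the high reading depends on the hydroxy group specifically. An amine or a carboxylic acid in place of the hydroxy group on the side chain would test that, and any such compound reading inside the range of the assay would give a step of readable size.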